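Hydroxamate sulfonamides: swapping a carbamate-bearing side chain

The source may hold more compounds than are shown below. What is called first, only, known or untested is meant among the compounds shown, and "the series" means these compounds.

Measured compounds:
- compound 1 `CCCC[C@H](NC(=O)OC(C)(C)C)C(=O)N[C@@H]1C[C@H](C(=O)NO)N(S(=O)(=O)c2ccc(OC)cc2)C1`: 131 nM
- compound 2 `COc1ccc(S(=O)(=O)N2C[C@H](NC(=O)CCCNC(=O)OC(C)(C)C)C[C@@H]2C(=O)NO)cc1`: 49 nM

Both compounds were tested in an assay on isolated protein for inhibition of matrix metalloproteinase-9 (Homo sapiens), read by fluorescence; on this read-out lower numbers stand for stronger inhibition and higher numbers for weaker inhibition. Compound 2 gives 49 nM, the lowest of the two numbers, while compound 1 gives 131 nM, a gap that lies beyond the usual scatter. Compound 3 `CCCC[C@H](N)C(=O)N[C@@H]1C[C@H](C(=O)NO)N(S(=O)(=O)c2ccc(OC)cc2)C1` has not yet been measured. It differs from compound 2 in one place: 1-aminopentyl in place of 3-((tert-butoxycarbonyl)amino)propyl on a carbonyl carbon. For the measured compounds named here, no step between measured compounds covers this exact change, so the expectation rests on compound 1, whose side chain carries the same 1-aminopentyl skeleton but capped as a carbamate and which gives 131 nM. Compound 3 is expected to show a weakening step a 4.1-fold higher number from compound 2 to compound 3 (0.61 log units; beyond the scatter) relative to compound 2, landing near compound 1 or somewhat weaker. The estimate for compound 3 in this assay is 200 nM, with a range from 50 nM to 800 nM.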

Compound 3, half-maximal inhibitory concentration: 98 nM
Compound 3: the middle estimate sits 2.0-fold (0.31 log units) above what was measured, within the range that was stated.
By their numbers in this assay, from the lowest: compounds 2, 3 and 1 (each within the scatter of the next, the first and the last beyond it).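

In this assay hydrogen in place of tert-butoxycarbonyl on an amine nitrogen gives a 1.3-fold lower number from compound 1 to compound 3 (0.13 log units; within the scatter) and so shows that this cap can be exchanged without a difference that stands clear of the scatter. Setting 1-aminopentyl in place of 3-((tert-butoxycarbonyl)amino)propyl on a carbonyl carbon gives a 2.0-fold higher number from compound 2 to compound 3 (0.30 log units; within the scatter) as well, so these two side chains are not told apart at this position in this assay. Nothing given here explains why these numbers stay so close.

The compounds shown leave open how an acetyl group on the amine nitrogen would read. They also leave open what the other configuration at the defined stereocentre of the 1-aminopentyl group, or a longer chain carrying the same free amine, would give.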